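The source may hold more compounds than are shown below. What is called first, only, known or untested is meant among the compounds shown, and "the series" means these compounds.

Measured compounds:
Compound 1 `COc1cc(C)cc(-c2c(-c3ccnc(-c4ccc(C(C)=O)cc4)c3)cnn2CC#N)c1` gives 88% in a functional assay on UACC-62 cells (Homo sapiens) for cytotoxicity, read by sulforhodamine B assay, with a stated time of 48 h, tested at 0.01 uM; on this read-out lower numbers stand for a stronger effect and higher numbers for a weaker effect at the one concentration tested.
Compound 2 `Cc1cc(O)cc(-c2nn(CC#N)cc2-c2ccnc(-c3ccc(Oc4ccccc4)cc3)c2)c1` gives 84% in this assay.
Compound 3 `COc1cc(C)cc(-c2nn(CC#N)cc2-c2ccnc(-c3ccc(N(C)C)cc3)c2)c1` gives 86% in this assay.

These three compounds share one core and differ in the groups hung on it. In this assay compound 3 reads a little below compound 1 and a little above compound 2, but each of those gaps lies within the usual scatter of repeated measurements, so the three numbers cannot be told apart: all three compounds leave the cells close to fully viable at the single concentration tested.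

Compound 4 `Cc1cc(O)cc(-c2nn(CC#N)cc2-c2ccnc(-c3ccc(N(C)C)cc3)c2)c1` has not yet been measured. It is reached from compound 3 by one change: hydrogen in place of methyl on an oxygen on an aromatic ring. Compound 2 already carries this hydroxy in place of the methoxy, and in this assay compound 2 gives 84%, which differs from compound 3 only within the scatter. Within the data shown here, nothing among the measured compounds suggests that this change moves the read-out. For the step from compound 3 to compound 4 in this assay, the expectation is therefore a change of no more than the scatter, in either direction.

Compound 4 is thus expected to give 85% in this assay, with a likely range from 72% to 97%, meaning an expected step of a number 1 percentage points lower from compound 3 to compound 4 (within the scatter).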

Compound 4, a percentage reported as activity, at one concentration (the size of the read-out at that concentration, not a potency): 96%
For compound 4 the middle estimate is 11 percentage points below the measured one; the range from low to high includes it.
By their numbers in this assay, from the lowest: compounds 2, 3, 1 and 4 (each within the scatter of the next, the first and the last beyond it).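

The step from methoxy to hydroxy can now be read on its own, with the dimethylamino group held fixed: a number 10 percentage points higher from compound 3 to compound 4 (within the scatter) in this assay and, taken alone, this single change on the 3-methoxy-5-methylphenyl group cannot be told from repeated-measurement noise. Compound 2 could not show this earlier, as it differs from compound 3 in two places. With the hydroxy now held fixed instead, dimethylamino in place of phenoxy on an aromatic carbon gives a number 12 percentage points higher from compound 2 to compound 4 (beyond the scatter) in this assay as a modest step, the only one here that clears the scatter, so the other end of the molecule can shift this read-out slightly, though nothing measured here accounts for either step.

Among these compounds, whether hydrogen in place of methyl on this oxygen reads the same with phenoxy or acetyl at that other place remains open, since only one pair isolates the change, and at a single concentration these numbers say nothing about potency. Also open, going by these compounds, is what an amino group or a longer ethoxy chain would read in place of the hydroxy on this aromatic ring.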